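Stereocentre configuration in the cyclic urea series

This account rests on a few compounds, and the source may have more. Where it says the series, first, only, none or still open, it means among the compounds named here.

Measured compounds:
Compound 1 `O=C1NC[C@@](COCc2cc(C(F)(F)F)cc(C(F)(F)F)c2)(c2ccc(F)cc2)N1` — in an assay on CHO cells for displacement of a labelled ligand from Substance-P receptor (Homo sapiens) (a lower number here means a stronger inhibitor, a higher number a weaker inhibitor), compound 1 gives 2.7 nM.
Compound 2 `O=C1NC[C@](COCc2cc(C(F)(F)F)cc(C(F)(F)F)c2)(c2ccc(F)cc2)N1` — in this assay compound 2 gives 89 nM.

Among the measured compounds shown here, compound 2 stands as the higher of the two numbers; its nearest neighbour is compound 1, and the step of a 33-fold higher number from compound 1 to compound 2 (1.52 log units; beyond the scatter) is the only measured step in the set. The two differ only in the configuration drawn at the saturated ring carbon, so the step itself is the evidence the fact that compounds 1 and 2 differ only in the configuration as drawn that configuration at this centre matters strongly.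

Compound 3 `O=C1NCC(COCc2cc(C(F)(F)F)cc(C(F)(F)F)c2)(c2ccc(F)cc2)N1` is the same structure drawn without a configuration at that carbon: the two compounds have the same atoms and bonds; at least one stereo element is drawn with a configuration in one of them and without one in the other: 1 of 1 stereo elements differ; a stereocentre at a saturated ring carbon is drawn S in compound 2 and without a configuration in compound 3. Such a drawing may represent both configurations present together. If so, its number should fall between compound 1 and compound 2, nearer to compound 1, since the lower number dominates a mixture. Compound 3 is therefore expected to show a marked drop from compound 2, the step of a 16-fold lower number from compound 2 to compound 3 (1.21 log units; beyond the scatter). Compound 3 is estimated at 5.5 nM, range 2.5 nM to 14 nM.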

Compound 3, inhibition constant: 4.5 nM
For compound 3 the middle estimate is 1.2-fold (0.09 log units) above the measured one; measured number inside the range.
By their numbers in this assay, from the lowest: compounds 1 and 3 (each within the scatter of the next); then compound 2.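

In this assay, the drawing without a configuration groups with the R-drawn form and not the S-drawn one: a 20-fold lower number from compound 2 to compound 3 (1.30 log units; beyond the scatter), whereas a 1.7-fold higher number from compound 1 to compound 3 (0.22 log units; within the scatter). The drawn configuration at this saturated ring carbon therefore separates compound 2 from the other two compounds, while compound 1 and compound 3 cannot be told apart in this assay. If compound 3 holds both configurations, these numbers fit the R-drawn form setting its reading, but its composition is not given, so this remains a conditional reading.

On these data alone, the exact makeup of compound 3 stays open. As far as these compounds go, it also remains open whether the gap between the R and S drawings persists with an amine or a carboxylic acid in place of the fluorine on the aryl group, or with a longer chain in place of the ether link.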